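Swapping the benzimidazole for a dimethylpyrazole on the acetamide arm

A few compounds are considered here, and "the series" means these few. Any claim that something is new, unique, unknown or untested is made for them only; others in the source may bear on it.

Measured so far:
Compound 1, `C[C@@H]1CN(c2sc(CN(C)C)nc2-c2nc3ccccc3[nH]2)CCN1C(=O)Cn1cnc2cccnc21`: 1150 nM
Compound 2, `CCOc1ncc(-c2nc(C(F)(F)F)sc2N2CCN(C(=O)Cn3cnc4ccccc43)[C@H](C)C2)cn1`: 192 nM

Of the compounds shown here, two have been measured in an assay on blood for inhibition of C-X-C chemokine receptor type 3 (Homo sapiens), with a stated time of 30 min; on this read-out higher numbers stand for weaker inhibition and lower numbers for stronger inhibition. Compound 1 gives 1150 nM, and compound 2 gives 192 nM. Compound 2 therefore holds the lower of the two numbers, and the gap to compound 1 is beyond the scatter of the read-out, though the two compounds differ in several places at once, so no single change can be held responsible.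

Compound 3, `CCOc1ncc(-c2nc(C(F)(F)F)sc2N2CCN(C(=O)Cn3nc(C)cc3C)[C@H](C)C2)cn1`, has not yet been measured. It differs from compound 2 in one place: 3,5-dimethyl-1H-pyrazol-1-yl in place of 1H-benzimidazol-1-yl on a saturated chain carbon bound to a carbonyl carbon. Within the data shown here, no step between measured compounds matches this change, so the size of its effect is open. The fused bicyclic group of compound 2 is replaced by a single five-membered ring carrying two methyl groups; the chain and the carbonyl stay as they are.

Compound 3 is expected to give 500 nM in this assay, with a plausible range from 150 nM to 1800 nM. This corresponds to an estimated step of a 2.6-fold higher number from compound 2 to compound 3 (0.42 log units; beyond the scatter), a modest loss that could still fall within the scatter.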

Compound 3, half-maximal inhibitory concentration: 60 nM
Estimate against measurement, compound 3: 8.3-fold (0.92 log units) above; measured number below the stated range.
By their numbers in this assay, from the lowest: compound 3; then compound 2; then compound 1.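

At this position, on a saturated chain carbon bound to a carbonyl carbon, this assay shows that 3,5-dimethyl-1H-pyrazol-1-yl in place of 1H-benzimidazol-1-yl gives a 3.2-fold lower number from compound 2 to compound 3 (0.51 log units; beyond the scatter) so the six-membered aromatic ring of carbon only is not needed for the lower number here, and a single five-membered aromatic ring with two added methyl groups does better within this pair. The exchange goes from 9 to 7 heavy atoms while the counts of hydrogen-bond donors and acceptors stay the same, so the gain comes with a smaller group and no change in those counts, something the earlier pair could not show since compound 1 and compound 2 differ in several places at once. No measurement is available that bears on why this exchange lowers the number, so the step stands as an observation only.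

The compounds shown do not separate the contribution of the two methyl groups from that of the pyrazole ring itself, which a plain 1H-pyrazol-1-yl group or a 1H-imidazol-1-yl group would address. They also leave open whether the same exchange would lower the number on the core of compound 1, with its dimethylaminomethyl group in place of trifluoromethyl.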